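Removing the aromatic methyl in the ketoacid series

The source may report more compounds than this note shows. Statements on the series, on what has been measured and on what is new or still open speak of the compounds shown alone.

The series is built around the core of compound 1 `O=C(O)/C=C/C(=O)c1ccccc1`; in a physicochemical assay for lipophilicity (a higher number here means a more lipophilic compound, a lower number a more polar compound), compound 1 gives 1.94. Going by the values given here, compound 3 `O=C(O)/C=C/C(=O)c1ccc(-c2ccccc2)cc1` gives 3.9, and the single change between them, a number 1.96 log units higher from compound 1 to compound 3 (beyond the scatter), is the only step so far measured in one place. Compound 2 `C/C(=C\C(=O)O)C(=O)c1ccc(C)cc1` gives 2.94 and stands second highest of the three numbers, nearer to compound 3 than to compound 1; it differs from compound 1 in two places, so its gap to either neighbour is not read as a single step.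

Compound 4 `C/C(=C\C(=O)O)C(=O)c1ccccc1` differs from compound 2 by hydrogen in place of methyl on an aromatic carbon. The measured step from compound 1 to compound 3 bears on it only loosely: it shows that adding carbon on the aromatic ring raises the number in this assay, and the present change goes the other way, taking one carbon off the ring. A smaller step is expected here, downward.

For compound 4 the estimate in this assay is 2.44, with a range from 2.1 to 2.8, which corresponds to an expected step of a number 0.50 log units lower from compound 2 to compound 4 (beyond the scatter).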

Compound 4, partition coefficient: 2.44
Estimate against measurement, compound 4: no gap at the digits printed, and the stated range covers the measured number.
By their numbers in this assay, from the lowest: compound 1; then compound 4; then compound 2; then compound 3.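

At this aromatic carbon, para to a group of 8 heavy atoms, hydrogen in place of methyl gives a modest step in this assay, a number 0.50 log units lower from compound 2 to compound 4 (beyond the scatter). Going by these compounds alone, this is the first single-place reading at this position on the background of compound 2, and it joins the larger step with phenyl on the core of compound 1, a number 1.96 log units higher from compound 1 to compound 3 (beyond the scatter), so that both changes at this position lie beyond the scatter. Nothing measured here gives a cause for either step.

Only hydrogen, methyl and phenyl appear at this position, so the two steps describe hydrocarbon groups alone. From the compounds shown here alone, how an amine, a methoxy group or a chlorine atom at the same carbon would read in this assay stays open, as does whether a longer chain would continue the trend.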